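Aryl group swaps on the double-bonded chain

The source may report more compounds than this note shows. Statements on the series, on what has been measured and on what is new or still open speak of the compounds shown alone.

In a functional assay on PC-3 cells (Homo sapiens) for cytotoxicity, read by MTT assay, with a stated time of 48 h (on this read-out higher numbers stand for weaker inhibition and lower numbers for stronger inhibition), compound 1 `CC1(C)CCC[C@]2(C)[C@@H](CC[C@@](C)(O)/C=C/c3ccc(Cl)nc3)[C@](C)(O)CC[C@@H]12` gives 275 nM, compound 2 `CC(C)(C)c1ccc(/C=C/[C@](C)(O)CC[C@@H]2[C@@]3(C)CCCC(C)(C)[C@@H]3CC[C@@]2(C)O)cc1` gives 3800 nM and compound 3 `COc1cccc(/C=C/[C@](C)(O)CC[C@@H]2[C@@]3(C)CCCC(C)(C)[C@@H]3CC[C@@]2(C)O)c1OC` gives 2900 nM. Compound 3 stands with compound 2 at the high end of these numbers, the gap between them being a 1.3-fold lower number from compound 2 to compound 3 (0.12 log units; within the scatter). Compound 1 lies well apart, with an 11-fold higher number from compound 1 to compound 3 (1.02 log units; beyond the scatter) and a 14-fold higher number from compound 1 to compound 2 (1.14 log units; beyond the scatter).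

The next structure is compound 4 `CC1(C)CCC[C@]2(C)[C@@H](CC[C@@](C)(O)/C=C/c3ccc(C(=O)O)cc3)[C@](C)(O)CC[C@@H]12`, which has 4-carboxyphenyl in place of 2,3-dimethoxyphenyl on a double-bonded chain carbon bound to a double-bonded chain carbon.

The two large steps both leave 6-chloropyridin-3-yl, which is not involved in this change, so they bear on it only weakly. Within the data shown here, the closest precedent is the exchange of one substituted phenyl group for another, which gave a 1.3-fold lower number from compound 2 to compound 3 (0.12 log units; within the scatter). Among the measured compounds shown here, no compound with 4-carboxyphenyl has been measured, so the uncertainty is wide. No step beyond the scatter is expected in this assay, and the expected step is a 1.2-fold higher number from compound 3 to compound 4 (0.08 log units; within the scatter). Compound 4 is estimated at 3500 nM, within an expected range of 1200 nM to 10000 nM.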

Compound 4, half-maximal inhibitory concentration: 102 nM
Compound 4: middle estimate off by 34-fold (1.54 log units), on the high side, and the stated range ends above it.
By their numbers in this assay, from the lowest: compound 4; then compound 1; then compounds 3 and 2 (each within the scatter of the next).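

In this assay the group on this double-bonded chain carbon proves able to move the number strongly among substituted phenyl groups, with 4-carboxyphenyl in place of 2,3-dimethoxyphenyl giving a 28-fold lower number from compound 3 to compound 4 (1.45 log units; beyond the scatter) and carboxy in place of tert-butyl on an aromatic carbon giving a 37-fold lower number from compound 2 to compound 4 (1.57 log units; beyond the scatter) in the same direction. The change also carries the series past the 6-chloropyridin-3-yl group, a modest gain seen as a 2.7-fold lower number from compound 1 to compound 4 (0.43 log units; beyond the scatter) and one that places compound 4 lowest of the four, with every step to it beyond the scatter. No measurement at hand bears on why the carboxy group has this effect.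

Going by these compounds, whether the gain needs the carboxylic acid itself remains open, and a methyl ester or primary amide on the same aromatic carbon would test this. Also open, on these data alone, is whether a carboxylic acid on a longer chain would hold the gain.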